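The source may hold more compounds than are shown below. What is called first, only, known or untested is meant among the compounds shown, and "the series" means these compounds.

Compound 2 `CCCOc1nc2c(c(=O)n(C)c(=O)n2C)n1CCCC(=O)Nc1ccc(C(C)CC)cc1` gives 9060 nM in an assay on isolated protein for inhibition of high affinity 3',5'-cyclic-AMP phosphodiesterase 7A (Homo sapiens), read by cAMP accumulation, with a stated time of 10 min; on this read-out higher numbers stand for weaker inhibition and lower numbers for stronger inhibition. For the measured compounds named here, it stands beside the only other number, that of compound 1 `CCCOc1nc2c(c(=O)n(C)c(=O)n2C)n1CCCC(=O)Nc1ccc(C(C)(C)C)cc1`, which gives 7760 nM in this assay; the step of a 1.2-fold higher number from compound 1 to compound 2 (0.07 log units; within the scatter) sits within the scatter. Compound 3 `CCCCOc1nc2c(c(=O)n(C)c(=O)n2C)n1CCCC(=O)Nc1ccc(C(C)CC)cc1` differs from compound 2 by methyl in place of hydrogen on a saturated chain carbon, three bonds along the chain from an oxygen on an aromatic ring. Going by the values given here, no measured step touches this part of the shared core, and the one recorded step lies elsewhere and within the scatter, so no direction can be read from it. The expected step of a 1.0-fold lower number from compound 2 to compound 3 (0.00 log units; within the scatter) is therefore none beyond the scatter. Compound 3 is estimated at 9000 nM, between 4500 nM and 18000 nM.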

Compound 3, half-maximal inhibitory concentration: 20000 nM
Estimate against measurement, compound 3: 2.2-fold (0.35 log units) below; the whole stated range lies below it.
By their numbers in this assay, from the lowest: compounds 1 and 2 (each within the scatter of the next); then compound 3.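

Methyl in place of hydrogen on this saturated chain carbon, three bonds along the chain from an oxygen on an aromatic ring, turns propyl to butyl and gives a 2.2-fold higher number from compound 2 to compound 3 (0.34 log units; beyond the scatter) in this assay. Unlike the earlier step on the aromatic carbon, this one lies beyond the scatter, so this position responds to a single added carbon, if modestly. Nothing available explains the rise.

Going by these compounds, whether ethyl or a longer chain such as pentyl continues this trend remains open. So does whether the step holds with the tert-butyl of compound 1.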